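Sulfoxide chain replaces methylsulfanyl on a shared core

A few compounds are considered here, and "the series" means these few. Any claim that something is new, unique, unknown or untested is made for them only; others in the source may bear on it.

The series is followed in a functional assay on the whole organism with Rattus norvegicus as the target; on this read-out higher numbers stand for an effect only at larger amounts of compound and lower numbers for an effect already at smaller amounts. Compound 1 `Nc1nc2ccc(OC(F)(F)C(F)(F)F)cc2s1` gives 2.5 mg/kg. Compound 2 `CSCn1c(=N)sc2cc(OC(F)(F)F)ccc21` gives 3 mg/kg, the higher of the two numbers, though its gap to compound 1 lies within the scatter, so no order between the two is claimed. For compound 3 `CN(C)CCn1c(=N)sc2ccccc21` this assay reports only a limit, > 10 mg/kg, rather than a number; that point is the limit of > 10 mg/kg in this assay, at which 1 of the 3 values shown sits.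

The unmeasured compound 4 `CC[S+]([O-])CCn1c(=N)sc2cc(OC(F)(F)F)ccc21` differs from compound 2 in one place: a group of 5 heavy atoms (3 carbon, 1 oxygen, 1 sulfur; no ring) in place of a group of 2 heavy atoms (1 carbon, 1 sulfur; no ring), on a saturated chain carbon bound to an aromatic nitrogen. For the measured compounds named here, no measured pair in this set separates this kind of exchange from other changes, so the step from compound 2 to compound 4 must be guessed from the three numbers alone. The author expects a small step toward a higher number, a 1.7-fold higher number from compound 2 to compound 4 (0.22 log units; within the scatter), not clearly beyond the scatter. On that basis compound 4 is estimated at 5 mg/kg in this assay, within a range from 2 mg/kg to 12 mg/kg.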

Compound 4, dose for half-maximal effect: 1.2 mg/kg
Compound 4: the middle estimate sits 4.2-fold (0.62 log units) above what was measured, outside the stated range (below it).
By their numbers in this assay, from the lowest: compound 4; then compounds 1 and 2 (each within the scatter of the next). At a limit, above all of these: compound 3.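

In this assay, for the compounds shown here, the exchange gives a 2.5-fold lower number from compound 2 to compound 4 (0.40 log units; beyond the scatter) and is the first step that can be read at this place, on a saturated chain carbon bound to an aromatic nitrogen. It shows that this place accepts a longer sulfoxide chain in place of methylsulfanyl with the number going down beyond the scatter, while the two groups have the same counts of hydrogen-bond donors and acceptors. Nothing measured here accounts for the step.

This single exchange changes the chain length and adds the oxygen on sulfur together, so the compounds shown do not separate the two. On these data alone, how a sulfide with the same chain, a sulfone or a carboxylic acid would read at this place remains open.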